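The source may report more compounds than this note shows. Statements on the series, on what has been measured and on what is new or still open speak of the compounds shown alone.

Measured so far:

Compound 1 `COc1ccc(Nc2nc(-n3cnc4ccccc43)cs2)cc1`: > 100000 nM
Compound 2 `Cc1nc2ccccc2n1-c1csc(Nc2ccc(Br)cc2)n1`: 90 nM
Compound 3 `COc1ccc(Nc2nc(-n3ccnc3C)cs2)cc1`: 1600 nM

All three were tested in a functional assay on RKO cells (Homo sapiens) for cytotoxicity, read by resazurin assay, with a stated time of 72 h; on this read-out higher numbers stand for weaker inhibition and lower numbers for stronger inhibition. Compound 1 gives no number there, only a limit: the limit of > 100000 nM in this assay, at which 1 of the 3 values shown sits. Compound 2 and compound 3 both give numbers in this assay, and compound 2 gives 90 nM while compound 3 gives 1600 nM. No two of these compounds differ in only one place, so no measured step can be followed between them.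

Compound 4 `c1ccc(Nc2nc(-n3cnc4ccccc43)cs2)cc1` is not yet measured. It differs from compound 1 by hydrogen in place of methoxy on an aromatic carbon. Compound 1 sits at the limit of this assay, so the direction of the change cannot be read from a measured step. The step from compound 1 to compound 4 is expected to be an at least 5.0-fold lower number from compound 1 to compound 4 (0.69 log units; beyond the scatter), downward from the limit, with wide uncertainty. Compound 4 is therefore expected to give about 20000 nM in this assay, within a range from 1000 nM to 100000 nM.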

Compound 4, half-maximal inhibitory concentration: > 100000 nM
Compound 4: no number, only a limit; the forecaster's own chance of this, stated with the estimate: 45%; middle value at least 5.0-fold (0.69 log units) away from the limit.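

Compound 1 and compound 4 both give only a limit in this assay, so no step can be read between them: the limit of > 100000 nM in this assay, at which 2 of the 4 values shown sit. The compounds shown leave open whether hydrogen in place of methoxy changes the cytotoxicity read-out at all.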